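The source may hold more compounds than are shown below. What is called first, only, known or untested is meant among the compounds shown, and "the series" means these compounds.

Measured so far:
compound 1, `COCCOc1cc2nccc(Oc3ccc(Nc4nccc5[nH]cc(-c6ccc(F)cc6)c(=O)c45)cc3F)c2cc1OC`, in a functional assay on HT-29 cells (Homo sapiens) for antiproliferative activity, read by MTT assay, with a stated time of 72 h (a higher number here means a weaker inhibitor, a lower number a stronger inhibitor), compound 1 gives 4600 nM
compound 2, `O=c1c(-c2ccc(F)cc2)c[nH]c2ccnc(Nc3ccc(Oc4ccnc5cc(OCCO)ccc45)c(F)c3)c12`, in this assay compound 2 gives 5500 nM

The two numbers lie within the scatter of each other, so compound 2 does not stand apart from compound 1 on the numbers shown; both sit at the weak end of what this assay reads. Compound 3, `CC(O)COc1ccc2c(Oc3ccc(Nc4nccc5[nH]cc(-c6ccc(F)cc6)c(=O)c45)cc3F)ccnc2c1`, is not yet measured. It differs from compound 2 as follows: methyl in place of hydrogen on a saturated chain carbon bound to an oxygen on a saturated carbon and a saturated chain carbon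

For the measured compounds named here, nothing measured here isolates this change, so no step of known size supports a prediction. The difference is small and sits at the chain end; the expectation is no step beyond the scatter in this assay, in either direction. For compound 3 in this assay the estimate is 5000 nM, with a range from 2500 nM to 10000 nM, which is expected to mean a step of a 1.1-fold lower number from compound 2 to compound 3 (0.04 log units; within the scatter).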

Compound 3, half-maximal inhibitory concentration: 3900 nM
Compound 3: middle estimate off by 1.3-fold (0.11 log units), on the high side; the measured number falls inside the stated range.
By their numbers in this assay, from the lowest: compounds 3, 1 and 2 (each within the scatter of the next).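

In this assay, for the compounds shown here, the change from 2-hydroxyethoxy to 2-hydroxypropoxy gives a 1.4-fold lower number from compound 2 to compound 3 (0.15 log units; within the scatter), the first single-place step. A methyl in place of hydrogen on this saturated chain carbon therefore leaves the number within the scatter, so this carbon accepts the one added carbon without a readable change. Nothing on hand bears on what lies behind this result.

Still open, going by these compounds, is whether a larger change at the chain end, such as an amine or a carboxylic acid in place of the hydroxyl, or a longer chain, would produce a step beyond the scatter in this assay. A single step also cannot show whether a second methyl on this same carbon would read the same way.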